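Notes on the step from compound 1 to compound 4

A few compounds are considered here, and "the series" means these few. Any claim that something is new, unique, unknown or untested is made for them only; others in the source may bear on it.

Measured in a functional assay on SH-SY5Y cells (Homo sapiens) for antiproliferative activity, read by MTT assay, with a stated time of 72 h; on this read-out lower numbers stand for stronger inhibition and higher numbers for weaker inhibition:
- compound 1 `COc1cc2c(Nc3ccc(C#N)cc3)ncnc2cc1OCCCN1CCC(C)CC1`: 7900 nM
- compound 2 `COc1cc2c(Nc3ccc(C#N)cc3)ncnc2cc1OCCCN1CCC(CO)CC1`: 21600 nM
- compound 3 `COc1cc2c(Nc3ccc(C#N)cc3)ncnc2cc1OCCCN1CCC(c2ccccc2)CC1`: 7770 nM

Compound 1 stands with compound 3 at the low end of these numbers, the two lying within the scatter of each other, while compound 2 has the highest number. Still unmeasured is compound 4 `COc1cc2c(Nc3ccc(C#N)cc3)ncnc2cc1OCCCN1CCC(N(C)C)CC1`, with dimethylamino in place of methyl on a saturated ring carbon. For the measured compounds named here, two measured steps bear on this change. Phenyl in place of methyl gave a 1.0-fold lower number from compound 1 to compound 3 (0.01 log units; within the scatter), so replacing methyl with a larger group need not move the number. Hydroxy in place of hydrogen gave a 2.7-fold higher number from compound 1 to compound 2 (0.44 log units; beyond the scatter), and this is the only measured change here that adds an atom other than carbon. Two steps are thin support, but a small rise in this assay is expected, no larger than the hydroxy step and possibly within the scatter. The expected step is a 1.5-fold higher number from compound 1 to compound 4 (0.18 log units; within the scatter). For compound 4 the estimated value is 12000 nM, with an expected range of 5500 nM to 26000 nM.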

Compound 4, half-maximal inhibitory concentration: 24300 nM
Compound 4: middle estimate off by 2.0-fold (0.31 log units), on the low side; low and high end bracket the measured number.
By their numbers in this assay, from the lowest: compounds 3 and 1 (each within the scatter of the next); then compounds 2 and 4 (each within the scatter of the next).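

In this assay, dimethylamino on the saturated ring carbon three ring bonds from the ring nitrogen gives a 3.1-fold higher number from compound 1 to compound 4 (0.49 log units; beyond the scatter) and a 3.1-fold higher number from compound 3 to compound 4 (0.50 log units; beyond the scatter) so the flat step seen on going from methyl to phenyl does not extend to every group at this position. Dimethylamino and hydroxymethyl give a 1.1-fold higher number from compound 2 to compound 4 (0.05 log units; within the scatter) so across these four compounds the two groups containing an atom other than carbon lie within the scatter of each other, the all-carbon methyl and phenyl do likewise, and each of the two carbon-only compounds has a lower number than either of the others by more than the scatter. No measurement available here accounts for this split.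

The compounds shown leave open whether the split follows the presence of nitrogen or oxygen in the group or something else, which methoxy or primary amino on the same carbon would test. Also open, on these data alone, is whether a longer all-carbon chain such as butyl stays with methyl and phenyl.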